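From Compound 2 to Compound 4: An Expectation

This account rests on a few compounds, and the source may have more. Where it says the series, first, only, none or still open, it means among the compounds named here.

Compound 1 `C/N=C(\S)NCCCCn1nc(C)ccc1=O` gives > 100 mg/kg in a functional assay on the whole organism (stomach) with Rattus norvegicus as the target (on this read-out higher numbers stand for an effect only at larger amounts of compound and lower numbers for an effect already at smaller amounts), a limit and not a number.
Compound 2 `CCC/N=C(/NC#N)NCCCCCn1nc(-c2ccccc2)ccc1=O` gives > 100 mg/kg in this assay, again a limit.
Compound 3 `C/N=C(/NC#N)NCCCCn1nc(Nc2ccccc2)ccc1=O` gives > 100 mg/kg in this assay, again a limit.

Compound 2 therefore stands at a limit in this assay, and no number is known for it. Among the measured compounds shown here, the same is true of compound 1 and of compound 3, so that every value so far sits at the limit of > 100 mg/kg in this assay, at which 3 of the 3 values shown sit. For the measured compounds named here, no pair of measured compounds differs in a single place, and so no measured step exists from which the size of a change could be read.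

Compound 4 `N#CNC(=N)NCCCCCn1nc(-c2ccccc2)ccc1=O` is still to be measured in this assay. It differs from compound 2 as follows: a group of 5 heavy atoms (2 carbon, 3 nitrogen; no ring) in place of a group of 8 heavy atoms (5 carbon, 3 nitrogen; no ring), on an amine nitrogen. With all three measured compounds at the limit, there is nothing to suggest a shift beyond the scatter in either direction, and the step of a number no higher from compound 2 to compound 4 (the limit leaves the size open) is expected to stay within the scatter. Compound 4 is therefore expected to give about 100 mg/kg in this assay, most likely reported again as a limit, with a range from 40 mg/kg to 300 mg/kg.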

Compound 4, dose for half-maximal effect: > 100 mg/kg
Compound 4 was reported as a limit; the forecaster's own chance of this, stated with the estimate: 75%; the middle value sits exactly at the limit.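

In this assay compound 4 gives > 100 mg/kg, which is a limit. Among the compounds shown here, compound 2 also stands at a limit, so no step between compound 2 and compound 4 can be read. The compounds shown leave open whether any of them has a half-maximal dose that can be given as a number, and how much the group on the amine nitrogen matters.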